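Replacing a Methyl with Propylsulfonyl on a Weak Compound

The compounds below may be only part of what the source reports. "The series", "measured", "known", "first", "only" and "open" are said of these compounds alone.

Measured compounds:
- compound 1, `Fc1ccccc1Cn1nc(-c2ncccn2)c2cccnc21`: 1250 nM
- compound 2, `Cc1cnc(-c2nn(Cc3ccccc3F)c3ncccc23)nc1N`: 675000 nM

Compound 1 is the more potent of the two in a functional assay (aorta) with Oryctolagus cuniculus as the target (on this read-out lower numbers stand for stronger inhibition and higher numbers for weaker inhibition), with 1250 nM. Among the measured compounds shown here, compound 2 stands highest of the two numbers, giving 675000 nM; its only neighbour is compound 1, and the one measured step, a 540-fold higher number from compound 1 to compound 2 (2.73 log units; beyond the scatter), is large. Compound 3, `CCCS(=O)(=O)c1cnc(-c2nn(Cc3ccccc3F)c3ncccc23)nc1N`, is not yet measured. It differs from compound 2 in one place: propylsulfonyl in place of methyl on an aromatic carbon.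

For the measured compounds named here, no measured step touches this change; the single known step concerns a different group, so it shows only that changes on this ring can move the number a long way, not in which direction this one will. The expectation is therefore a step of uncertain direction, a 1.7-fold lower number from compound 2 to compound 3 (0.23 log units; within the scatter), with a wide range. Compound 3 is estimated at 400000 nM, between 40000 nM and 2000000 nM.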

Compound 3, half-maximal inhibitory concentration: 378000 nM
Beside the measured number, compound 3's estimate is 1.1-fold (0.02 log units) above it; measured number inside the range.
By their numbers in this assay, from the lowest: compound 1; then compounds 3 and 2 (each within the scatter of the next).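

In this assay the exchange of methyl for propylsulfonyl gives a 1.8-fold lower number from compound 2 to compound 3 (0.25 log units; within the scatter) and so no real difference between the two compounds. This position on the ring, ortho to an amino group, therefore accepts a chain of 6 heavy atoms with 2 hydrogen-bond acceptors in place of a single carbon, and the reading stays where it was. No available measurement bears on why that is so.

The step of a 540-fold higher number from compound 1 to compound 2 (2.73 log units; beyond the scatter) brings in the amino group and the methyl together, so the compounds shown leave open which of the two carries that large change. They also leave open whether an amine, a carboxylic acid or a longer chain at this position would stay level with compound 2 as well.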